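Oxadiazole series, cytotoxicity on breast cancer cells

This account rests on a few compounds, and the source may have more. Where it says the series, first, only, none or still open, it means among the compounds named here.

Measured so far:
compound 1 `Cc1ccc(C)c(N2CCN(Cc3nnc(-c4cc(S(N)(=O)=O)c(SCc5ccccc5)cc4Cl)o3)CC2)c1`: 51000 nM
compound 2 `NS(=O)(=O)c1cc(-c2nnc(Cn3cc(-c4ccccc4)nn3)o2)c(Cl)cc1SCc1ccccc1`: 170000 nM

In a functional assay on MCF7 cells (Homo sapiens) for cytotoxicity, read by MTT assay, with a stated time of 72 h (on this read-out lower numbers stand for stronger inhibition and higher numbers for weaker inhibition), compound 1 gives 51000 nM and compound 2 gives 170000 nM. Compound 2 stands at the highest, that is weakest, of the two numbers; its gap to compound 1 lies beyond the usual scatter, so compound 2 is the weaker of the two on this read-out.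

Compound 3 `NS(=O)(=O)c1cc(-c2nnc(/C=C/c3ccc(Cl)cc3)o2)c(Cl)cc1SCc1ccccc1` is not yet measured. It differs from compound 2 in one place: 2-(4-chlorophenyl)ethenyl in place of (4-phenyl-1H-1,2,3-triazol-1-yl)methyl on an aromatic carbon. For the measured compounds named here, no step between measured compounds that matches this change is available, so the expectation rests only on the two values above, both of which sit far up in the weak range.

Given that compound 2 gives 170000 nM, a number for compound 3 that is somewhat lower is expected, but the step is estimated to stay close to the scatter, as a 2.1-fold lower number from compound 2 to compound 3 (0.33 log units; beyond the scatter). For compound 3 a value of 80000 nM is estimated, with a range from 25000 nM to 250000 nM.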

Compound 3, half-maximal inhibitory concentration: 11000 nM
Estimate against measurement, compound 3: 7.3-fold (0.86 log units) above, outside the stated range (below it).
By their numbers in this assay, from the lowest: compound 3; then compound 1; then compound 2.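

In this assay the aromatic carbon of the five-membered ring with 2 nitrogen and 1 oxygen proves sensitive to its substituent: 2-(4-chlorophenyl)ethenyl in place of (4-phenyl-1H-1,2,3-triazol-1-yl)methyl gives a 15-fold lower number from compound 2 to compound 3 (1.19 log units; beyond the scatter) and moves the series out of the range set by the earlier values. The change is not a single one, as the entering group has fewer heavy atoms than the group it replaces, 0 hydrogen-bond acceptors against 3, one aromatic ring instead of two, a chlorine and a double bond outside aromatic rings, and this one step cannot assign the gain to any of these features. No measurement at hand accounts for the size of the step.

Open, from the compounds shown here alone, is whether the gain belongs to the ethenyl link or to the chlorine, which a plain 2-phenylethenyl group or a 2-(4-methoxyphenyl)ethenyl group at this place would help to separate. Also open, going by these compounds, is how a saturated 2-(4-chlorophenyl)ethyl chain would read here, and whether the double bond is needed at all.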